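Swapping One Ring on a Carbonyl Carbon

The compounds below may be only part of what the source reports. "The series", "measured", "known", "first", "only" and "open" are said of these compounds alone.

In a functional assay on HCT-116 cells (Homo sapiens) for inhibition, read by ELISA, with a stated time of 24 h (a higher number here means a weaker inhibitor of growth, a lower number a stronger inhibitor of growth), compound 1 (`CN1CCN(C(=O)ONC(=O)/C=C/c2ccccc2OC(=O)c2ccccc2)CC1`) gives 40400 nM and is the weaker of the two measured compounds. Compound 2 (`O=C(/C=C/c1ccccc1O)NO`) gives 16800 nM and this gap lies beyond the usual scatter. Compound 3 (`O=C(/C=C/c1ccccc1OC(=O)c1ccccc1)NOC(=O)N1CCOCC1`) has morpholin-4-yl in place of 4-methylpiperazin-1-yl on a carbonyl carbon and is otherwise the same as compound 1. Within the data shown here, no measured pair shows this swap. In this assay no change beyond the scatter is expected, and the estimated step of a 1.2-fold lower number from compound 1 to compound 3 (0.06 log units; within the scatter) is small and slightly downward. For compound 3 the expected value is 35000 nM within an estimated range of 15000 nM to 80000 nM overall.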

Compound 3, concentration for 50% growth inhibition: 12500 nM
Compound 3: middle estimate off by 2.8-fold (0.45 log units), on the high side; the whole stated range lies above it.
By their numbers in this assay, from the lowest: compounds 3 and 2 (each within the scatter of the next); then compound 1.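

Here the ring on this carbonyl carbon is shown to matter: in this assay, morpholin-4-yl in place of 4-methylpiperazin-1-yl gives a 3.2-fold lower number from compound 1 to compound 3 (0.51 log units; beyond the scatter) and so moves the number modestly. The change is small on paper, since one six-membered non-aromatic ring with 2 hetero atoms replaces another. Nothing measured here bears on the reason for this step.

From the compounds shown here alone, it remains open whether piperidin-1-yl, a ring with a single nitrogen, or an open-chain dimethylamino group would fit the same trend. Going by these compounds, whether the swap acts alike on another core also remains open.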